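This account rests on a few compounds, and the source may have more. Where it says the series, first, only, none or still open, it means among the compounds named here.

In a functional assay on A549 cells (Homo sapiens) for inhibition, read by sulforhodamine B assay, with a stated time of 72 h (on this read-out higher numbers stand for weaker inhibition and lower numbers for stronger inhibition), three compounds with a shared core have been measured. Compound 1 `Nc1sc(-c2ccc(Cl)cc2)c(-c2ccc(Cl)cc2)c1C(=O)N1CCCCC1=O` gives 1820 nM, compound 2 `CC1CN(C(=O)c2c(N)sc(-c3ccc(Cl)cc3)c2-c2ccc(Cl)cc2)CCN1` gives 4930 nM, and compound 3 `Nc1sc(-c2ccc(Cl)cc2)c(-c2ccc(Cl)cc2)c1C(=O)N1CCC(=O)CC1=O` gives 4090 nM. Compound 3 is level with compound 2 within the scatter, while both carry higher numbers than compound 1, beyond the scatter. Compound 4 `Nc1sc(-c2ccc(Cl)cc2)c(-c2ccc(Cl)cc2)c1C(=O)NC1CCCC1` alters only the group on a carbonyl carbon whose other neighbour is an aromatic carbon: cyclopentylamino in place of 2,4-dioxopiperidin-1-yl on a carbonyl carbon. The three measured steps all exchange a group at this same place, and they are small: a 2.7-fold higher number from compound 1 to compound 2 (0.43 log units; beyond the scatter), a 2.2-fold higher number from compound 1 to compound 3 (0.35 log units; beyond the scatter) and a 1.2-fold lower number from compound 2 to compound 3 (0.08 log units; within the scatter). Going by the values given here, none of them tests cyclopentylamino directly, so they offer only an indication of how far this place has moved the numbers so far. A small change is therefore expected, with no shift beyond the scatter, and the estimated step is a 1.4-fold lower number from compound 3 to compound 4 (0.13 log units; within the scatter). For compound 4 the expected value is 3000 nM, with an estimated range of 1000 nM to 9000 nM.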

Compound 4, half-maximal inhibitory concentration: 6790 nM
The estimate for compound 4 lay 2.3-fold (0.35 log units) below the measured number, within the range that was stated.
By their numbers in this assay, from the lowest: compound 1; then compounds 3, 2 and 4 (each within the scatter of the next).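

In this assay, going by these compounds alone, cyclopentylamino, the first group here with a ring of carbon only, stays level with both the 2,4-dioxopiperidin-1-yl group (a 1.7-fold higher number from compound 3 to compound 4 (0.22 log units; within the scatter)) and the 3-methylpiperazin-1-yl group (a 1.4-fold higher number from compound 2 to compound 4 (0.14 log units; within the scatter)). Only the 2-oxopiperidin-1-yl group stands apart from it (a 3.7-fold higher number from compound 1 to compound 4 (0.57 log units; beyond the scatter)), so compound 1 now has the lowest number, beyond the scatter from all three other compounds, and the three remaining groups cannot be ranked against one another. No available evidence accounts for this separation.

On these data alone, all four compounds differ only in the group on the carbonyl carbon, so what changes elsewhere on the shared core would do remains open. As far as these compounds go, it is also open whether an open-chain amine such as diethylamino, or a cyclopentylamino ring bearing a carboxylic acid, would stay level with this group of three or reach compound 1.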